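Swapping ethoxy for methylamino on compound 3

This account rests on a few compounds, and the source may have more. Where it says the series, first, only, none or still open, it means among the compounds named here.

Of the compounds shown here, three sharing one core have been measured in a physicochemical assay for lipophilicity, read by HPLC, at pH 7.5; on this read-out higher numbers stand for higher lipophilicity and lower numbers for lower lipophilicity. Compound 1 `CC[C@@H](Nc1c(C#N)c(-c2ccc(-c3ccccc3F)cc2)nc2cnccc12)C(N)=O` gives 2.7, compound 2 `CC[C@@H](Nc1c(C#N)c(-c2ccc(-c3ccncc3C)cc2)nc2cnccc12)C(N)=O` gives 2 and compound 3 `CCOc1ccccc1-c1ccc(-c2nc3cnccc3c(N[C@H](CC)C(N)=O)c2C#N)cc1` gives 3. Compound 3 cannot be told apart from compound 1, with a number 0.30 log units higher from compound 1 to compound 3 (within the scatter), but it stands clearly apart from compound 2, with a number 1.00 log units higher from compound 2 to compound 3 (beyond the scatter).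

Compound 4 `CC[C@@H](Nc1c(C#N)c(-c2ccc(-c3ccccc3NC)cc2)nc2cnccc12)C(N)=O` carries methylamino in place of ethoxy on an aromatic carbon. Within the data shown here, no measured step makes this exact exchange, so the guidance is indirect. Changing the group on this carbon-only ring, as ethoxy for fluoro, gave the small step above. Replacing the whole ring gave a number 0.70 log units lower from compound 1 to compound 2 (beyond the scatter), which is modest. Compound 4 keeps the carbon-only ring, so a step of that larger size seems less likely here.

The expected change in this assay is a small to modest drop: a number 0.40 log units lower from compound 3 to compound 4 (beyond the scatter). For compound 4 the estimated value is 2.6, with an expected range from 2.2 to 3.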

Compound 4, distribution coefficient: 2.5
Compound 4: the middle estimate sits 0.10 log units above what was measured, and the stated range covers the measured number.
By their numbers in this assay, from the lowest: compound 2; then compounds 4, 1 and 3 (each within the scatter of the next, the first and the last beyond it).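

Ethoxy and methylamino on this aromatic carbon can be told apart in this assay (a number 0.50 log units lower from compound 3 to compound 4 (beyond the scatter)), yet methylamino stays close to fluoro (a number 0.20 log units lower from compound 1 to compound 4 (within the scatter)), as ethoxy did. So two groups that each sit within the scatter of fluoro can still differ from each other by more than the scatter. The ring exchange from 3-methylpyridin-4-yl to 2-(methylamino)phenyl gives a number 0.50 log units higher from compound 2 to compound 4 (beyond the scatter) and also clears the scatter, but nothing measured here explains the size of any of these steps.

Still open, from the compounds shown here alone, is whether the chain length or the hydrogen on the nitrogen goes with the step from ethoxy to methylamino. Methoxy, with a shorter chain than ethoxy, and dimethylamino, with no hydrogen left on the nitrogen, would help to separate the two.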